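The source may hold more compounds than are shown below. What is called first, only, known or untested is meant among the compounds shown, and "the series" means these compounds.

Measured so far in a functional assay on NCI-H460 cells (Homo sapiens) for antiproliferative activity, read by CCK-8 assay, with a stated time of 72 h, tested at 2 uM; on this read-out lower numbers stand for a weaker effect and higher numbers for a stronger effect at the one concentration tested:

- compound 1, `Cc1ccc(Nc2nc(Cl)nc3c2ncn3Cc2ccc(C(=O)Nc3ccccc3N)cc2)cc1`: 67.3%
- compound 2, `Cc1ccc(Nc2nc(Cl)nc3c2ncn3Cc2ccc(/C=C/C(=O)Nc3ccccc3N)cc2)cc1`: 31.3%
- compound 3, `Nc1ccccc1NC(=O)c1ccc(CNc2nc(Cl)nc3c2ncn3Cc2ccccc2)cc1`: 43.8%

Compound 2 stands lowest of the three numbers in this assay. Going by the values given here, its nearest neighbour is compound 3, whose number lies higher by a margin beyond the scatter; the widest gap is to compound 1, and that gap is the one measured step, a number 36 percentage points lower from compound 1 to compound 2 (beyond the scatter), which concerns the linker between the shared core and the aminophenyl amide, not the aryl-amino end.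

Compound 4, `Nc1ccccc1NC(=O)/C=C/c1ccc(Cn2cnc3c(Nc4ccccc4)nc(Cl)nc32)cc1`, keeps the linker of compound 2 and changes only the aryl-amino end: hydrogen in place of methyl on an aromatic carbon.

Among the compounds with values here, no measured step touches this position. The step from compound 1 to compound 2 alters a different part of the molecule and gives no guidance on removing the methyl; compound 3 differs from compound 2 in more than one place, so only its value is available. With nothing bearing directly on the change, a step no larger than the scatter is expected in this assay, in either direction.

The estimate for compound 4 is therefore close to compound 2, at 30% with a range of 15% to 48%, meaning an expected step of a number 1.3 percentage points lower from compound 2 to compound 4 (within the scatter).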

Compound 4, a percentage reported as inhibition, at one concentration (the size of the read-out at that concentration, not a potency): 2.05%
Compound 4: middle estimate off by 28 percentage points, on the high side; the measured number lies below the stated range.
By their numbers in this assay, from the lowest: compound 4; then compound 2; then compound 3; then compound 1.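

In this assay the aryl-amino end is not a silent position: with the ethenyl linker held constant, hydrogen in place of methyl gives a number 29.3 percentage points lower from compound 2 to compound 4 (beyond the scatter), a step beyond the scatter from a change of one heavy atom on the ring. Going by these compounds alone, the earlier compounds offered only a step at the linker, so this is the first sign that the 4-methylphenyl end also carries weight, and with phenyl in place of 4-methylphenyl, compound 4 at 2.05% keeps very little of the read-out at the one concentration tested. Nothing at hand explains why this single methyl matters so much here.

Still open, as far as these compounds go, is whether the methyl counts for as much on the shorter linker of compound 1, since the step rests on one pair carrying the ethenyl linker and one concentration. Also open, from the compounds shown here alone, is how far the position tolerates other groups in place of the methyl, such as an ethyl, a methoxy or a chlorine, and whether any of them would lift the read-out above that of the methyl itself.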